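Furan-2-yl in place of ethynyl on the shared core

This account rests on a few compounds, and the source may have more. Where it says the series, first, only, none or still open, it means among the compounds named here.

Three compounds of the series have been run in a functional assay on HCT-116 cells (Homo sapiens), read by MTT assay, with a stated time of 72 h; a lower number here means a stronger inhibitor, a higher number a weaker inhibitor. Compound 1 `Nc1nc(N)c2c(-c3cc4ccccc4o3)cn([C@@H]3O[C@H](CO)[C@@H](O)[C@H]3O)c2n1` reaches only a limit of the assay in this assay, > 20000 nM, and is reported as no number. Compound 3 `CNc1ncnc2c1c(-c1ccsc1)cn2[C@@H]1O[C@H](CO)[C@@H](O)[C@H]1O` likewise returns a limit in this assay, > 20000 nM. Within the data shown here, compound 2 `C#Cc1cn([C@@H]2O[C@H](CO)[C@@H](O)[C@H]2O)c2ncnc(OC)c12` is the only member with a numerical value, giving 4060 nM in this assay; it therefore stands as the one point of the series, with the other two sitting at the limit of > 20000 nM in this assay, at which 2 of the 3 values shown sit.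

Compound 4 `COc1ncnc2c1c(-c1ccco1)cn2[C@@H]1O[C@H](CO)[C@@H](O)[C@H]1O` has not been measured. It differs from compound 2 by furan-2-yl in place of ethynyl on an aromatic carbon. Within the series, the two compounds carrying a five-membered aromatic ring at this position, compound 1 and compound 3, both sit at the limit, though their cores differ from that of compound 2 in other places as well, so no single-change step is available. The expectation for compound 4 is a weakening: an estimated step of a 3.0-fold higher number from compound 2 to compound 4 (0.47 log units; beyond the scatter) beyond the usual scatter, with a fair chance that only a limit is returned. Compound 4 is estimated at 12000 nM in this assay, expected to fall between 4000 nM and 30000 nM.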

Compound 4, half-maximal inhibitory concentration: 40 nM
Beside the measured number, compound 4's estimate is 300-fold (2.48 log units) above it; measured number outside the range, below it.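

In this assay, among these compounds, furan-2-yl in place of ethynyl on this aromatic carbon gives a 100-fold lower number from compound 2 to compound 4 (2.01 log units; beyond the scatter), the first single-change step, and it shows that the read-out at this position responds strongly to the group carried there. Compound 4 carries a five-membered aromatic ring at this position and still returns a number, so such a ring does not by itself lead to the assay limit. Compound 1 and compound 3 differ from compound 4 in more than one place, so steps to their limit values cannot be read: the limit of > 20000 nM in this assay, at which 2 of the 4 values shown sit.

As far as these compounds go, whether the ring oxygen of furan-2-yl matters or the aromatic ring alone is enough stays open; a phenyl group on the shared core would separate the two. From the compounds shown here alone, how an aminomethyl group or a longer alkyl chain at this carbon would read is also open.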